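Replacing a Chlorophenyl Amide with an Indole Amide

This account rests on a few compounds, and the source may have more. Where it says the series, first, only, none or still open, it means among the compounds named here.

Three compounds sharing one core, each carrying a basic amine on one side and an aromatic amide on the other, have been measured in a functional assay on SK-BR-3 cells (Homo sapiens) for antiproliferative activity, read by MTT assay, with a stated time of 72 h; on this read-out lower numbers stand for stronger inhibition and higher numbers for weaker inhibition. Compound 1 `Cc1cc(NCCN(C)C)nc2ccc(NC(=O)c3ccc(Cl)c(Cl)c3)cc12` gives 6670 nM. Within the data shown here, compound 2 `Cc1cc(NCCN2CCN(C)CC2)nc2ccc(NC(=O)c3ccc(Cl)c(Cl)c3)cc12` gives 2690 nM, and the only single-point step measured so far is a 2.5-fold lower number from compound 1 to compound 2 (0.39 log units; beyond the scatter), a change on the amine side. Compound 3 `CCN1CCN(c2cc(C)c3cc(NC(=O)c4ccc(Cl)cc4)ccc3n2)CC1` gives 3020 nM, the second highest of the three numbers: it sits within the scatter of compound 2 and clearly below compound 1.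

Compound 4 `CCN1CCN(c2cc(C)c3cc(NC(=O)c4cc5ccccc5[nH]4)ccc3n2)CC1` differs from compound 3 in one place: 1H-indol-2-yl in place of 4-chlorophenyl on a carbonyl carbon. Among the measured compounds shown here, no measured step bears on this part of the molecule; the one step known concerns the amine chain and offers no guide to what an exchange of the group on the carbonyl carbon does. With nothing to lean on, the step of a 1.2-fold lower number from compound 3 to compound 4 (0.08 log units; within the scatter) is expected to stay within the usual scatter, with a wide margin of uncertainty in either direction. Compound 4 is therefore estimated at 2500 nM, in a range from 600 nM to 10000 nM.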

Compound 4, half-maximal inhibitory concentration: 2550 nM
The estimate for compound 4 lay 1.0-fold (0.01 log units) below the measured number; measured number inside the range.
By their numbers in this assay, from the lowest: compounds 4, 2 and 3 (each within the scatter of the next); then compound 1.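

In this assay, the group on the carbonyl carbon can be exchanged without a change that stands out from the scatter: the step is a 1.2-fold lower number from compound 3 to compound 4 (0.07 log units; within the scatter). The exchange itself is not a small one on paper, since 1H-indol-2-yl has 9 heavy atoms against 7 in 4-chlorophenyl, adds a five-membered aromatic ring, brings in 1 hydrogen-bond donor and removes the chlorine, so for this pair, all of these differences together leave the number within the scatter. No measurement at hand explains this outcome, and the pair alone cannot show whether the contributions of these differences are each negligible or offset one another.

Two aromatic groups say little about the position as a whole, and a cyclohexyl group, with no aromatic ring at all, or a 1-methylindol-2-yl group, which has a methyl in place of the indole hydrogen, would test it more sharply. On these data alone, it also remains open whether the same exchange behaves alike with a different amine on the other side of the shared core, such as the 2-(dimethylamino)ethylamino chain of compound 1.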